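Outlook for compound 4 after compound 3 sits at the limit

This account rests on a few compounds, and the source may have more. Where it says the series, first, only, none or still open, it means among the compounds named here.

Compound 3 `COc1cc(C2=C(c3ccccc3)C(O[SiH2]C(C)(C)C)CC2=O)cc(OC)c1OC` is the reference point here. In an ADME assay on MIA PaCa-2 cells (Homo sapiens) for cytotoxicity, read by MTT assay, with a stated time of 72 h (on this read-out higher numbers stand for weaker inhibition and lower numbers for stronger inhibition), compound 3 gives > 100 ug/mL, which is a limit of the assay and not a number. Compound 1 `COC(=O)c1cc(C2=C(c3cc(OC)c(OC)c(OC)c3)C(=O)CC2O[SiH2]C(C)(C)C)ccc1OC` gives in this assay > 100 ug/mL, likewise a limit. Compound 2 `COc1ccc(C2=C(c3cc(OC)c(OC)c(OC)c3)C(=O)CC2O[SiH2]C(C)(C)C)cc1OC` gives in this assay > 100 ug/mL, again a limit. The three steps among these compounds stay unreadable because the limit of > 100 ug/mL in this assay, at which 3 of the 3 values shown sit, stands at both ends of each: a step that the two limits leave unreadable from compound 1 to compound 3, a step that the two limits leave unreadable from compound 2 to compound 3 and a step that the two limits leave unreadable from compound 1 to compound 2.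

Compound 4 `COCOc1cc(C2=C(c3cc(OC)c(OC)c(OC)c3)C(=O)CC2O[SiH2]C(C)(C)C)ccc1OC` differs from compound 3 by 4-methoxy-3-(methoxymethoxy)phenyl in place of phenyl on a double-bonded ring carbon. Within the data shown here, the steps that bear on this change are those in which phenyl was exchanged against 3,4-dimethoxyphenyl or against 4-methoxy-3-(methoxycarbonyl)phenyl on the same double-bonded ring carbon, a step that the two limits leave unreadable from compound 2 to compound 3 and a step that the two limits leave unreadable from compound 1 to compound 3; neither yields a size, and both leave the reading at the limit. No step beyond the scatter is therefore expected in this assay; the step from compound 3 to compound 4 is estimated as a number no higher from compound 3 to compound 4 (the limit leaves the size open). Compound 4 is accordingly expected at 100 ug/mL, within 50 ug/mL to 200 ug/mL, and most likely reported only as a limit once more.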

Compound 4, half-maximal inhibitory concentration: 50 ug/mL
Compound 4: the middle estimate sits 2.0-fold (0.30 log units) above what was measured; the measured number falls inside the stated range.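

In this assay, among these compounds, compound 4 gives 50 ug/mL, the only value shown that is a number and not a limit, so with 4-methoxy-3-(methoxymethoxy)phenyl on this double-bonded ring carbon the series has its first reading with a size. That reading does not yet establish a real change, since the new steps are floors only: an at least 2.0-fold lower number from compound 3 to compound 4 (0.30 log units; that floor lies within the scatter), an at least 2.0-fold lower number from compound 2 to compound 4 (0.30 log units; that floor lies within the scatter) and an at least 2.0-fold lower number from compound 1 to compound 4 (0.30 log units; that floor lies within the scatter). The steps among compound 1, compound 2 and compound 3 still cannot be read, and any comparison in the series rests on a single number set against limits: the limit of > 100 ug/mL in this assay, at which 3 of the 4 values shown sit.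

Going by these compounds, how far compound 4 truly stands from compound 1, compound 2 and compound 3 stays open, as does whether the change in the methoxymethoxy group itself or the whole exchanged aryl group carries any difference. Also open, on these data alone, is what a hydroxyl, an amine or a carboxylic acid would give in this assay on the aromatic carbon that carries methoxymethoxy in compound 4.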